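A few compounds are considered here, and "the series" means these few. Any claim that something is new, unique, unknown or untested is made for them only; others in the source may bear on it.

Measured in a functional assay on MCF7 cells (Homo sapiens) for cytotoxicity, read by MTT assay, with a stated time of 48 h; a lower number here means a stronger inhibitor, a higher number a weaker inhibitor:
Compound 1 `Fc1cccc(-c2nc(Nc3ccccc3)c3cc(F)ccc3n2)c1`: 49700 nM
Compound 2 `Fc1cccc(Nc2nc(-c3cccc(F)c3)nc3ccc(F)cc23)c1`: 48700 nM
Compound 3 `Fc1cccc(-c2nc(Nc3ccc(Cl)cc3)c3cc(F)ccc3n2)c1`: > 50000 nM, a limit of the assay and not a number

Among the compounds with values here, compound 2 holds one of only two true numbers in this assay, and the step of a 1.0-fold lower number from compound 1 to compound 2 (0.01 log units; within the scatter) leaves it level with compound 1. The third value, that of compound 3, is only a limit.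

Compound 4 `Oc1ccc(Nc2nc(-c3cccc(F)c3)nc3ccc(F)cc23)cc1` differs from compound 2 by 4-hydroxyphenyl in place of 3-fluorophenyl on a nitrogen on an aromatic ring. The measured change closest to this one is an at least 1.0-fold higher number from compound 2 to compound 3 (0.01 log units; that floor lies within the scatter), which replaces the same 3-fluorophenyl with 4-chlorophenyl. From the compounds shown here alone, the size of that step stays open, since it rests on a limit. The same holds for the step of a number no lower from compound 1 to compound 3 (the limit leaves the size open), which adds chloro in place of hydrogen on an aromatic carbon. Within the data shown here, no measured compound carries a 4-hydroxyphenyl group, so the new group is untested here, and the range must stay wide.

On this evidence, no step beyond the scatter is expected in this assay. The expected change is a 1.3-fold lower number from compound 2 to compound 4 (0.11 log units; within the scatter). Compound 4 is estimated at 38000 nM, with an expected range from 14000 nM to 60000 nM.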

Compound 4, half-maximal inhibitory concentration: > 50000 nM
Compound 4: only a limit was reported; the forecaster's own chance of this, stated with the estimate: 35%; at least 1.3-fold (0.11 log units) between middle value and limit.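

In this assay compound 4 gives > 50000 nM, a limit of the assay and not a number. The new steps that can be read are an at least 1.0-fold higher number from compound 2 to compound 4 (0.01 log units; that floor lies within the scatter) and a number no lower from compound 1 to compound 4 (the limit leaves the size open). The first of these shows that 4-hydroxyphenyl, with its hydrogen-bond donor and acceptor, gives no lower number than 3-fluorophenyl on this nitrogen; the step that links compound 4 to compound 3 cannot be read. With 4-chlorophenyl in compound 3 and 4-hydroxyphenyl in compound 4, two different groups at this place now end at the same ceiling of the assay: the limit of > 50000 nM in this assay, at which 2 of the 4 values shown sit.

The compounds shown leave open how far past that limit compound 3 and compound 4 lie, and so whether the two differ at all. Also open, from the compounds shown here alone, is whether an amine, a methoxy group or a carboxylic acid in place of the hydroxy would give a number clearly lower than the two true numbers in this assay, which are joined by a 1.0-fold lower number from compound 1 to compound 2 (0.01 log units; within the scatter).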